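Chain removal in the series: working notes

The compounds below may be only part of what the source reports. "The series", "measured", "known", "first", "only" and "open" are said of these compounds alone.

Measured so far in a physicochemical assay for lipophilicity, using the shake flask method, in phosphate buffer, measured as octanol-water partition, at pH 7.4; on this read-out higher numbers stand for higher lipophilicity and lower numbers for lower lipophilicity:
- compound 1 `CC[C@H](c1ccc(C(=O)O)c(Oc2cccc(Cl)c2)c1F)N1CCC[C@H](n2cc(C)c(=O)[nH]c2=O)C1` gives 0.12
- compound 2 `CCC[C@H](c1ccc(C(=O)O)c(Oc2cccc(Cl)c2)c1OC)N1CCC[C@H](n2cc(C)c(=O)[nH]c2=O)C1` gives 0.08
- compound 3 `CCC[C@H](c1ccc(C(=O)O)c(Oc2cccc(Cl)c2)c1F)N1CCC[C@H](n2cc(C)c(=O)[nH]c2=O)C1` gives 0.53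

Compound 1 and compound 2 lie within the scatter of each other, and the gap to the third is a number 0.45 log units higher from compound 2 to compound 3 (beyond the scatter) with a change on an aromatic carbon. Compound 4 `COc1c(CN2CCC[C@H](n3cc(C)c(=O)[nH]c3=O)C2)ccc(C(=O)O)c1Oc1cccc(Cl)c1` comes from compound 2 by hydrogen in place of propyl on a saturated chain carbon bound to an amine nitrogen in a ring and an aromatic carbon with hydrogen in place of propyl on a saturated chain carbon bound to an amine nitrogen in a ring and an aromatic carbon. Within the data shown here, the only measured step on that chain is a number 0.41 log units higher from compound 1 to compound 3 (beyond the scatter) for a single methyl, and no measured step removes a whole propyl. Read in reverse over the larger group, that step points to a fall in this assay beyond the scatter and larger than itself. The expected step is a number 0.88 log units lower from compound 2 to compound 4 (beyond the scatter) in size. Compound 4 is estimated at -0.8 with an expected range from -1.4 to -0.3 on this scale.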

Compound 4, distribution coefficient: -0.77
The estimate for compound 4 lay 0.03 log units below the measured number; the range from low to high includes it.
By their numbers in this assay, from the lowest: compound 4; then compounds 2 and 1 (each within the scatter of the next); then compound 3.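

In this assay, among these compounds, the reading of a number 0.85 log units lower from compound 2 to compound 4 (beyond the scatter) is the first measured removal of a whole propyl on a saturated chain carbon bound to an amine nitrogen in a ring and an aromatic carbon, and it applies with methoxy on the aromatic carbon. The methyl step, a number 0.41 log units higher from compound 1 to compound 3 (beyond the scatter) with fluoro on that aromatic carbon, therefore comes from a different setting. No supporting measurement bears on why the number moves.

From the compounds shown here alone, whether hydrogen in place of propyl gives a step of similar size with fluoro remains open. So does the effect of a butyl chain or a cyclopropyl group on this carbon.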